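From compound 3 to compound 4: clearance notes

The compounds below may be only part of what the source reports. "The series", "measured", "known", "first", "only" and "open" are said of these compounds alone.

The compounds share one core and differ on a saturated chain carbon bound to a carbonyl carbon and an oxygen on a saturated carbon. The read-out is an ADME assay on liver for metabolic stability, with Liver microsome (Homo sapiens) as the target, read by LC-MS, using microsomes; a higher number here means faster removal of the compound, a lower number slower removal. Compound 3 (`O=C(NCc1cc(Cl)ccc1-n1cnnn1)[C@@H]1C[C@@H]2C[C@@H]2N1C(=O)[C@H](O)c1ccccc1F`) gives < 12 mL.min-1.g-1, which is a limit of the assay and not a number. Compound 1 (`O=C(NCc1cc(Cl)ccc1-n1cnnn1)[C@@H]1C[C@@H]2C[C@@H]2N1C(=O)[C@H](O)CC1CC1`) gives < 12 mL.min-1.g-1, which is also a limit. Compound 2 (`CC(C)(C)OC[C@@H](O)C(=O)N1[C@H](C(=O)NCc2cc(Cl)ccc2-n2cnnn2)C[C@@H]2C[C@@H]21`) gives 21 mL.min-1.g-1, the only one of the three reported as a number. The data are thus dominated by the limit of < 12 mL.min-1.g-1 in this assay, at which 2 of the 3 values shown sit.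

Compound 4 (`O=C(NCc1cc(Cl)ccc1-n1cnnn1)[C@@H]1C[C@@H]2C[C@@H]2N1C(=O)[C@H](O)Cc1ccccn1`) carries (pyridin-2-yl)methyl in place of 2-fluorophenyl on a saturated chain carbon bound to a carbonyl carbon and an oxygen on a saturated carbon.

Among the measured compounds shown here, three measured steps bear on this change. Putting tert-butoxy in place of cyclopropyl gives an at least 1.7-fold higher number from compound 1 to compound 2 (0.24 log units; that floor lies within the scatter). Putting 2-fluorophenyl in place of (tert-butoxy)methyl gives an at least 1.7-fold lower number from compound 2 to compound 3 (0.24 log units; that floor lies within the scatter). Putting 2-fluorophenyl in place of cyclopropylmethyl gives a step that the two limits leave unreadable from compound 1 to compound 3. None of these steps is shown to exceed the scatter, so no step beyond the scatter, in either direction, is expected in this assay. The estimated step is a number no lower from compound 3 to compound 4 (the limit leaves the size open). For compound 4 the estimated value is 12 mL.min-1.g-1, with an expected range from 7 mL.min-1.g-1 to 24 mL.min-1.g-1.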

Compound 4, intrinsic clearance in microsomes: 17 mL.min-1.g-1
For compound 4 the middle estimate is 1.4-fold (0.15 log units) below the measured one; the range from low to high includes it.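

In this assay the (pyridin-2-yl)methyl group gives a reported number at this position, where the 2-fluorophenyl and cyclopropylmethyl groups gave only limits. Pyridin-2-yl in place of tert-butoxy gives a 1.2-fold lower number from compound 2 to compound 4 (0.09 log units; within the scatter), so the two groups that give numbers cannot be told apart in this read-out. Against the two compounds held at a limit, the new group gives an at least 1.4-fold higher number from compound 3 to compound 4 (0.15 log units; that floor lies within the scatter) and an at least 1.4-fold higher number from compound 1 to compound 4 (0.15 log units; that floor lies within the scatter); both floors lie within the scatter, so neither shows a change beyond it, and their true size stays open because both rest on one shared limit: the limit of < 12 mL.min-1.g-1 in this assay, at which 2 of the 4 values shown sit.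

The change from 2-fluorophenyl to (pyridin-2-yl)methyl replaces the ring and its link to the chain carbon in a single step, so the ring nitrogen and the link cannot be separated; a benzyl group on the same carbon would divide the two. As far as these compounds go, whether any group at this position moves clearance beyond the scatter also remains open, and an amine or a carboxylic acid on this chain would extend the comparison to groups of a different kind.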